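The source may hold more compounds than are shown below. What is called first, only, known or untested is meant among the compounds shown, and "the series" means these compounds.

Compound 1, `O=C(COc1ccncc1-c1ccc2ccccc2c1)N1CCOCC1`, gives 9% in an assay on a protein complex for inhibition of CDK8/Cyclin C (Homo sapiens), with a stated time of 1 h, tested at 10 uM; a lower number here means less inhibition, a higher number more inhibition at the concentration tested (going by the name of the read-out).
Compound 2, `NNC(=O)COc1ccncc1-c1ccc2ccccc2c1`, gives 19% in this assay.
Compound 3, `O=C(O)/C=C/c1ccncc1-c1ccc2ccccc2c1`, gives 102% in this assay.

Compound 3 stands highest of the three numbers; its nearest neighbour is compound 2, which lies beyond the scatter below it, and compound 1 lies further away still. Compound 4, `NC(=O)/C=C/c1ccncc1-c1ccc2ccccc2c1`, has not yet been measured. It differs from compound 3 in one place: amino in place of hydroxy on a carbonyl carbon. The change sits on the carbonyl carbon of the 2-carboxyethenyl group, which keeps its other neighbour, the double-bonded chain carbon.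

Two measured steps exist. The step of a number 10 percentage points higher from compound 1 to compound 2 (within the scatter) also exchanged the group on a carbonyl carbon and stayed within the scatter. The step of a number 83 percentage points higher from compound 2 to compound 3 (beyond the scatter) was large, but it put 2-carboxyethenyl in place of (aminocarbamoyl)methoxy as a whole, so it does not isolate the carboxy to carbamoyl exchange. Among the compounds with values here, no measured pair tests that exchange directly. Within the data shown here, because the only comparable step, a number 10 percentage points higher from compound 1 to compound 2 (within the scatter), stayed within the scatter, a modest step is expected in this assay, most likely downward from the high value of compound 3. Compound 4 is therefore expected to give 72%, within a range from 38% to 100%, which would mean an estimated step of a number 30 percentage points lower from compound 3 to compound 4 (beyond the scatter).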

Compound 4, a percentage reported as inhibition, at one concentration (the size of the read-out at that concentration, not a potency): 102%
The estimate for compound 4 lay 30 percentage points below the measured number; the whole stated range lies below it.
By their numbers in this assay, from the lowest: compounds 1 and 2 (each within the scatter of the next); then compounds 3 and 4 (each within the scatter of the next).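

In this assay, within the data shown here, the exchange of hydroxy for amino on the carbonyl carbon, carboxy to carbamoyl in the side chain, isolated here for the first time, gives no change at the digits printed from compound 3 to compound 4 (within the scatter). The step from the (aminocarbamoyl)methoxy group to 2-carbamoylethenyl on an aromatic carbon gives a number 83 percentage points higher from compound 2 to compound 4 (beyond the scatter), so among these compounds the large rise seen with 2-carboxyethenyl does not depend on the carboxy group and holds equally for the carbamoyl group. Nothing measured here bears on the reason for either step.

The read-out comes from a single concentration and is not a potency, so the identical numbers leave open whether compound 3 and compound 4 would separate at lower concentrations. As far as these compounds go, it also remains open whether a methyl ester, a nitrile or a dimethylamino group on the carbonyl carbon would hold the number as well, and whether the ethenyl link itself is needed, which a saturated ethyl link carrying the same carbamoyl group would test.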